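Swapping the carbamate ester group on the piperidine nitrogen

The source may hold more compounds than are shown below. What is called first, only, known or untested is meant among the compounds shown, and "the series" means these compounds.

Measured compounds:
compound 1, `Cc1nc(S(C)(=O)=O)ccc1Oc1ncnc(OC2CCN(C(=O)OC3CCC3)CC2)c1F`, 167 nM
compound 2, `Cc1nc(S(C)(=O)=O)ccc1Oc1ncnc(OC2CCN(C(=O)O[C@H](C)CF)CC2)c1F`, 1520 nM
compound 3, `Cc1nc(S(C)(=O)=O)ccc1Oc1ncnc(OC2CCN(C(=O)OC3(C(F)(F)F)COC3)CC2)c1F`, 342 nM

All three share one core and differ only in the group carried on the ring nitrogen. In a functional assay on isolated protein for inhibition of Glucose-dependent insulinotropic receptor (Rattus norvegicus), read by HTRF and cAMP accumulation (a higher number here means that more compound is needed for the effect, a lower number that less compound is needed), compound 3 gives 342 nM, the second highest of the three numbers: compound 1 sits lower, a 2.0-fold higher number from compound 1 to compound 3 (0.31 log units; beyond the scatter), and compound 2 sits higher, a 4.4-fold lower number from compound 2 to compound 3 (0.65 log units; beyond the scatter). Compound 4, `Cc1nc(S(C)(=O)=O)ccc1Oc1ncnc(OC2CCN(C(=S)OC3(C)CC3)CC2)c1F`, has not been measured. It differs from compound 3 in that (a group of 7 heavy atoms (5 carbon, 1 oxygen, 1 sulfur; one three-membered non-aromatic ring of carbon only) in place of a group of 11 heavy atoms (5 carbon, 3 oxygen, 3 fluorine; one four-membered non-aromatic ring with 1 hetero atom), on an amine nitrogen in a ring); at the same time the carbonyl is replaced by a thiocarbonyl. The two measured steps show that a small ring on the ester oxygen went with lower numbers than an open chain, and the entering group is again a small ring, as in compound 1. Nothing measured covers the sulfur. A modest drop from compound 3 to compound 4 is therefore expected, a 1.4-fold lower number from compound 3 to compound 4 (0.14 log units; within the scatter), with a wide range. Compound 4 is estimated at 250 nM, between 60 nM and 1200 nM.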

Compound 4, half-maximal effective concentration: 48.8 nM
For compound 4 the middle estimate is 5.1-fold (0.71 log units) above the measured one; the measured number lies below the stated range.
By their numbers in this assay, from the lowest: compound 4; then compound 1; then compound 3; then compound 2.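

In this assay the group with a thiocarbonyl and a three-membered carbon ring gives the lowest number of the four compounds: a 7.0-fold lower number from compound 3 to compound 4 (0.85 log units; beyond the scatter) and a 3.4-fold lower number from compound 1 to compound 4 (0.53 log units; beyond the scatter) and also a 31-fold lower number from compound 2 to compound 4 (1.49 log units; beyond the scatter) all lie beyond the scatter. This position, on an amine nitrogen in a ring, therefore accepts sulfur in place of the carbonyl oxygen with no loss here, and the numbers reach lower than the cyclobutyl carbamate of compound 1 had shown. The ring and the thiocarbonyl enter together, and nothing available explains the drop.

The compounds shown leave open which of the two changes carries the drop, a question that a cyclobutyl group on the thiocarbonyl or a three-membered carbon ring on the plain carbonyl would address. They also leave open whether an amine nitrogen in place of the ester oxygen, giving a urea, would fit this position.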